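Bromo added to the benzyl-bearing analogue: an expectation

The compounds below may be only part of what the source reports. "The series", "measured", "known", "first", "only" and "open" are said of these compounds alone.

Compound 1 `NS(=O)(=O)c1ccc(/N=C2\NC(=O)/C(=C3/C(=O)Nc4ccc([N+](=O)[O-])cc43)S2)cc1`: 13800 nM
Compound 2 `NS(=O)(=O)c1ccc(/N=C2\NC(=O)/C(=C3/C(=O)N(Cc4ccccc4)c4ccccc43)S2)cc1`: > 200000 nM
Compound 3 `CN1C(=O)/C(=C2\S/C(=N/c3ccc(S(N)(=O)=O)cc3)NC2=O)c2ccccc21`: 163000 nM

In a functional assay on Caco-2 cells (Homo sapiens) for antiproliferative activity, read by MTT assay (a higher number here means a weaker inhibitor, a lower number a stronger inhibitor), compound 1 gives 13800 nM and compound 3 gives 163000 nM. For compound 2 the assay reports only a limit, not a number. Compound 2 therefore stands at the limit of > 200000 nM in this assay, at which 1 of the 3 values shown sits. Going by the values given here, the one measured step, an at least 1.2-fold lower number from compound 2 to compound 3 (0.08 log units; that floor lies within the scatter), removes a phenyl from a chain carbon and says nothing about a substituent on the aromatic ring. Compound 4 `NS(=O)(=O)c1ccc(/N=C2\NC(=O)/C(=C3/C(=O)N(Cc4ccccc4)c4ccc(Br)cc43)S2)cc1` differs from compound 2 by bromo in place of hydrogen on an aromatic carbon. Among the compounds with values here, no measured step bears on this change, so the expectation for compound 4 rests on compound 2 alone. The step expected is a number no higher from compound 2 to compound 4 (the limit leaves the size open), none beyond the scatter. Compound 4 is estimated at 200000 nM, between 50000 nM and 800000 nM, with a limit again likely.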

Compound 4, half-maximal inhibitory concentration: 57800 nM
Beside the measured number, compound 4's estimate is 3.5-fold (0.54 log units) above it, and the stated range covers the measured number.
By their numbers in this assay, from the lowest: compound 1; then compound 4; then compound 3. At a limit, above all of these: compound 2.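

In this assay, bromo in place of hydrogen on an aromatic carbon gives an at least 3.4-fold lower number from compound 2 to compound 4 (0.53 log units; beyond the scatter). This shows that the aromatic ring of the shared core, which the earlier step did not touch, responds to a substituent at this position. The true size of the step stays unknown because compound 2 stands at a limit, not a number: the limit of > 200000 nM in this assay, at which 1 of the 4 values shown sits.

Open, from the compounds shown here alone, is whether chloro, methoxy or an amine at this carbon would also give a lower number. Also open, going by these compounds, is whether bromo would have the same effect with methyl in place of benzyl, as in compound 3.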